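The source may hold more compounds than are shown below. What is called first, only, known or untested is meant among the compounds shown, and "the series" means these compounds.

Two measured compounds set the frame. Compound 1 `CCCN(CCC)c1c(C)nc(-c2c(C)cc(C)cc2OC)nc1OC(C)C` gives only a limit in an in vitro assay on IMR-32 cells for displacement of a labelled ligand from corticotropin-releasing factor receptor 1 (Homo sapiens) (a higher number here means a weaker inhibitor, a lower number a stronger inhibitor), namely > 5000 nM. Of the two values shown, one thus sits at the limit (the limit of > 5000 nM in this assay, at which 1 of the 2 values shown sits). Within the data shown here, compound 2 `CCC(CC)Oc1c(C)nc(-c2c(OC)cc(Cl)cc2OC)nc1OC` gives 9 nM in this assay and is the only compound with a number at all, so it stands as the sole reference point. Compound 3 `CCC(CC)Oc1c(C)nc(-c2c(OC)cc(C(F)F)cc2OC)nc1OC` differs from compound 2 by difluoromethyl in place of chloro on an aromatic carbon. Among the measured compounds shown here, no step between measured compounds is known, so the size of this change cannot be read from the data. The expected step of a 1.7-fold higher number from compound 2 to compound 3 (0.22 log units; within the scatter) is small and is not expected to exceed the usual scatter in either direction. For compound 3 the estimated value in this assay is 15 nM, expected to fall between 4 nM and 60 nM.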

Compound 3, inhibition constant: 9 nM
For compound 3 the middle estimate is 1.7-fold (0.22 log units) above the measured one; the measured number falls inside the stated range.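

Among these compounds, at this position, para to a large group and meta to two methoxy groups, the pair offers the first step that can be read on the shared core: in this assay there is no change at the digits printed from compound 2 to compound 3 (within the scatter) on replacing chloro with difluoromethyl. The exchange thus brings in more heavy atoms, carbon and fluorine where chlorine stood, with no hydrogen-bond donor or acceptor on either side, and the read-out gives no sign of a loss. Nothing in the data shown accounts for this outcome.

As far as these compounds go, whether trifluoromethyl, a nitrile or an amine would fare the same way at this position stays open. Compound 1 gives only a limit, > 5000 nM in this assay, and it differs from the others in more than one place, so steps to it cannot be read.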